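Swapping the chlorophenyl group for a methylfuran ring

A few compounds are considered here, and "the series" means these few. Any claim that something is new, unique, unknown or untested is made for them only; others in the source may bear on it.

All four compounds share one core and differ only in the group attached to a saturated ring carbon. Compound 1 `COc1cc(N2C(N)=C(C#N)C(c3ccc([N+](=O)[O-])cc3)C3=C2CC(C)(C)CC3=O)cc(OC)c1OC` carries a nitro group on that aromatic part; in a functional assay on Ehrlich cells (Mus musculus) for cytotoxicity (a lower number here means a stronger inhibitor, a higher number a weaker inhibitor), compound 1 gives 25000 nM. Compound 2 `COc1cc(N2C(N)=C(C#N)C(c3ccc(C)cc3)C3=C2CC(C)(C)CC3=O)cc(OC)c1OC` carries a methyl instead, and in this assay compound 2 gives 52900 nM. Going by the values given here, the one step that can be read directly, a 2.1-fold higher number from compound 1 to compound 2 (0.33 log units; beyond the scatter), is modest but beyond the scatter. Compound 3 `COc1cc(N2C(N)=C(C#N)C(c3ccccc3Cl)C3=C2CC(C)(C)CC3=O)cc(OC)c1OC` carries a 2-chlorophenyl group in the same place. In this assay compound 3 was reported as "not active" (no number reported), so no number stands for it. Compound 4 `COc1cc(N2C(N)=C(C#N)C(c3ccc(C)o3)C3=C2CC(C)(C)CC3=O)cc(OC)c1OC` makes the next change: 5-methylfuran-2-yl in place of 2-chlorophenyl on a saturated ring carbon. Among the compounds with values here, no measured step involves a chlorophenyl or a methylfuran group, so the step from compound 1 to compound 2 is the only guide to how much swapping this group moves the read-out, and it was small. Compound 3 offers no number to start from, so neither the direction nor the size of the step to compound 4 can be judged. The measured compounds all sit at weak potency, and compound 4 is expected to sit there too, at 40000 nM, within 10000 nM to 200000 nM, with a real chance that it also comes back without a number.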

Compound 4, half-maximal inhibitory concentration: 216000 nM
The estimate for compound 4 lay 5.4-fold (0.73 log units) below the measured number, and the stated range ends below it.
By their numbers in this assay, from the lowest: compound 1; then compound 2; then compound 4.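

At this saturated ring carbon, the 5-methylfuran-2-yl group gives a higher number in this assay than either of the two phenyl groups that carry a measured value, seen as a 4.1-fold higher number from compound 2 to compound 4 (0.61 log units; beyond the scatter) and as an 8.6-fold higher number from compound 1 to compound 4 (0.94 log units; beyond the scatter) in the same assay. Both steps lie beyond the usual scatter, so compound 4 is the weakest of the three compounds with a number, and this position does respond when a six-membered aromatic ring gives way to a five-membered one with an oxygen atom. Compound 3 has no number, so the step from it to compound 4 cannot be read, and nothing measured here says why the furan compound sits highest.

The compounds shown leave open whether the change follows from the furan ring itself or from its methyl group, since a furan without the methyl, or a thiophene, does not appear among them. They also leave open how this position would respond to a group of a different kind, such as a piperidine or a carboxylic acid.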